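Acetyl in Place of Hydrogen on a Ring Nitrogen

A few compounds are considered here, and "the series" means these few. Any claim that something is new, unique, unknown or untested is made for them only; others in the source may bear on it.

Two hydrazone-bearing compounds were tested in a functional assay on HepG2 cells (Homo sapiens) for cytotoxicity, read by XTT assay, with a stated time of 72 h; a higher number here means a weaker inhibitor, a lower number a stronger inhibitor. Compound 1 `COc1ccc(/C=N/Nc2nc(-c3ccccc3)c[se]2)cc1` gives 50500 nM. Compound 2 `ClCc1c[se]c(N/N=C/c2csc(-c3ccccc3)n2)n1` has a core that differs from that of compound 1 in a way not broken down here; in this assay compound 2 gives 18800 nM, the lowest of the two numbers. Compound 3 `COc1ccc(/C=N/N(C(C)=O)c2nc(-c3ccccc3)c[se]2)cc1` carries acetyl in place of hydrogen on a nitrogen on an aromatic ring. In this assay compound 3 reaches only a limit, > 62700 nM. The step of an at least 1.2-fold higher number from compound 1 to compound 3 (0.09 log units; that floor lies within the scatter) is known only as a floor because the limit of > 62700 nM in this assay, at which 1 of the 3 values shown sits, marks where the reading stopped. Compound 4 `CC(=O)N(/N=C/c1csc(-c2ccccc2)n1)c1nc(CCl)c[se]1` is made from compound 2 by the same change, (acetyl in place of hydrogen on a nitrogen on an aromatic ring). Resting on what compound 1 showed, an at least 1.2-fold higher number from compound 1 to compound 3 (0.09 log units; that floor lies within the scatter), the expected step is a 2.4-fold higher number from compound 2 to compound 4 (0.38 log units; beyond the scatter). Compound 4 is therefore estimated at 45000 nM, with a likely range from 20000 nM to 90000 nM.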

Compound 4, half-maximal inhibitory concentration: 19300 nM
Compound 4: the middle estimate sits 2.3-fold (0.37 log units) above what was measured; the measured number lies below the stated range.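

In this assay, acetyl in place of hydrogen on a nitrogen on an aromatic ring gives a 1.0-fold higher number from compound 2 to compound 4 (0.01 log units; within the scatter), so on this core the change leaves the reading within the usual scatter. Compound 3 stands at > 62700 nM, which is a limit and not a number. This pair therefore does not show that the change carries from one core to another with the same size, nor that it does not: the same change on two cores in this assay, an at least 1.2-fold higher number (0.09 log units; that floor lies within the scatter) from compound 1 to compound 3 and a 1.0-fold higher number (0.01 log units; within the scatter) from compound 2 to compound 4; the limit leaves it open whether they differ

The compounds shown leave open how a different group on that same nitrogen would read, such as methyl or a longer chain in place of acetyl. They also leave open whether the step would hold on a core carrying an amine or a carboxylic acid.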